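The source may hold more compounds than are shown below. What is called first, only, known or untested is meant among the compounds shown, and "the series" means these compounds.

This set concerns a cytotoxicity read-out in an ADME assay on MRC5 cells (Homo sapiens) for cytotoxicity, read by resazurin assay, with a stated time of 72 h; on this read-out lower numbers stand for stronger inhibition and higher numbers for weaker inhibition. Compound 1 has the structure `O=[N+]([O-])c1cn2c(n1)OC(COc1ccc(-c3ccc(F)nc3F)nc1)CC2`. Compound 2, with the structure `CC1(COc2ccc(-c3ccc(F)nc3F)nc2)CCn2cc([N+](=O)[O-])nc2O1`, shares the core of compound 1 but carries a methyl group; the change hydrogen in place of methyl on a saturated ring carbon turns compound 2 into compound 1. Compound 3 has the structure `CC1(COCc2ccc(-c3ccc(F)cc3)cc2)CCn2cc([N+](=O)[O-])nc2O1`; how its core differs from the core of compound 2 is not broken down here.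

In this assay compound 1 reaches only a limit, reported as > 64000 nM. Compound 2 likewise gives only a limit, > 64000 nM. Compound 3 also stops at a limit, > 64000 nM. Since both ends are limits, the step that the two limits leave unreadable from compound 2 to compound 1 cannot be read; all three values sit at the limit of > 64000 nM in this assay, at which 3 of the 3 values shown sit.

Compound 4, with the structure `O=[N+]([O-])c1cn2c(n1)OC(COCc1ccc(-c3ccc(F)cc3)cc1)CC2`, is not yet measured. It arises from compound 3 by hydrogen in place of methyl on a saturated ring carbon, the same change that leads from compound 2 to compound 1, made at a place described in identical words. Because compound 3 gives > 64000 nM, and because the measured pair of compounds 2 and 1 both sit at the limit of > 64000 nM in this assay, at which 3 of the 3 values shown sit, the step of a number no higher from compound 3 to compound 4 (the limit leaves the size open) is expected to be unreadable as well. For compound 4 the expected value is 64000 nM, most likely again a limit, with an estimated range from 32000 nM to 200000 nM.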

Compound 4, half-maximal inhibitory concentration: > 64000 nM
Compound 4: a limit, no number; the forecaster's own chance of this, stated with the estimate: 90%; the middle value lies on the limit itself.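

The step from compound 3 to compound 4 cannot be read, as both values in this assay are limits and not numbers, and all compounds shown end the same way: the limit of > 64000 nM in this assay, at which 4 of the 4 values shown sit.

What the compounds shown leave open is how far apart they truly lie, and whether swapping methyl for hydrogen on that saturated ring carbon changes cytotoxicity at all.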